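Swapping bromine for chlorine on a weakly cytotoxic compound

The source may report more compounds than this note shows. Statements on the series, on what has been measured and on what is new or still open speak of the compounds shown alone.

Measured so far:
compound 1, `CC(O)(CSc1ccc(Br)cc1)c1nc(-c2ccc([N+](=O)[O-])c(C(F)(F)F)c2)no1`: 51000 nM
compound 2, `CC(O)(CSc1ccc(F)cc1)c1nc(-c2ccc(F)c(Cl)c2)no1`: 11500 nM

In a functional assay on PC-3 cells (Homo sapiens) for cytotoxicity, read by MTT assay (a lower number here means a stronger inhibitor, a higher number a weaker inhibitor), compound 1 gives 51000 nM, the higher of the two numbers, while compound 2 gives 11500 nM, a gap beyond the usual scatter. Compound 3, `CC(O)(CSc1ccc(Cl)cc1)c1nc(-c2ccc([N+](=O)[O-])c(C(F)(F)F)c2)no1`, is not yet measured; it differs from compound 1 by chloro in place of bromo on an aromatic carbon. Nothing measured here shows how such a change plays out, so the step of a 1.1-fold higher number from compound 1 to compound 3 (0.03 log units; within the scatter) is expected to be small, not beyond the scatter, in either direction. Compound 3 is therefore estimated at 55000 nM, with a likely range from 20000 nM to 150000 nM.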

Compound 3, half-maximal inhibitory concentration: 3000 nM
Compound 3: middle estimate off by 18-fold (1.26 log units), on the high side; the measured number lies below the stated range.
By their numbers in this assay, from the lowest: compound 3; then compound 2; then compound 1.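

Chloro in place of bromo, on an aromatic carbon para to a large group, gives a 17-fold lower number from compound 1 to compound 3 (1.23 log units; beyond the scatter) in this assay even though only one halogen atom changes. This position is therefore sensitive: a single-atom swap here moves the number well beyond the scatter, something compounds 1 and 2 could not show because they differ in several places. Nothing available explains the size of this step. As far as these compounds go, whether a methoxy group or an amine at this position would lower the number further, or raise it again, remains open.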